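A few compounds are considered here, and "the series" means these few. Any claim that something is new, unique, unknown or untested is made for them only; others in the source may bear on it.

Measured so far: compound 1 `CN(Cc1cccc2ccccc12)Cc1cn(C)c2ccc(CNc3ccc(F)cc3)cc12` and compound 2 `CN1CCN(Cc2cn(C)c3ccc(C(=O)Nc4ccc(F)cc4)cc23)CC1`.

In a functional assay on HeLa cells (Homo sapiens) for antiproliferative activity, read by MTT assay, with a stated time of 72 h (on this read-out lower numbers stand for stronger inhibition and higher numbers for weaker inhibition), compound 1 gives 950 nM. In this assay compound 2 gives 24800 nM, the higher of the two numbers, beyond the scatter. Compound 3 `Cn1cc(CN2CCN(Cc3ccc(-c4ccccc4)cc3)CC2)c2cc(C(=O)Nc3ccc(F)cc3)ccc21` differs from compound 2 by 4-phenylphenyl in place of hydrogen on a saturated chain carbon bound to an amine nitrogen in a ring. Within the data shown here, no step between measured compounds bears on this change. A step in the direction of a lower number is expected, because compound 1, which carries a larger group at the basic nitrogen, gives 950 nM. For compound 3 the estimate is 4000 nM, within 900 nM to 18000 nM, an expected step of a 6.2-fold lower number from compound 2 to compound 3 (0.79 log units; beyond the scatter).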

Compound 3, half-maximal inhibitory concentration: 39700 nM
Estimate against measurement, compound 3: 9.9-fold (1.00 log units) below, outside the stated range (above it).
By their numbers in this assay, from the lowest: compound 1; then compounds 2 and 3 (each within the scatter of the next).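

Putting 4-phenylphenyl in place of hydrogen on a saturated chain carbon bound to an amine nitrogen in a ring gives a 1.6-fold higher number from compound 2 to compound 3 (0.20 log units; within the scatter) in this assay and so does not separate the two compounds. At this position, a group of 12 heavy atoms therefore leaves the read-out where hydrogen has it. No measurement on hand accounts for this result.

Compound 1 differs from compound 3 in more than one place, so its value cannot be tied to any single change. As far as these compounds go, whether a smaller group here, such as methyl or a single phenyl ring, would behave the same remains open.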